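The compounds below may be only part of what the source reports. "The series", "measured", "known", "first", "only" and "open" are said of these compounds alone.

Compound 1 `Cc1ccc(NC(=O)COc2ccc3cc(/C=C4/SC(=O)NC4=O)ccc3c2)cc1`: in an assay on isolated protein for inhibition of histone deacetylase 4 (Homo sapiens), with a stated time of 1 h (a higher number here means a weaker inhibitor, a lower number a stronger inhibitor), compound 1 gives 1700 nM.
Compound 2 `O=C(COc1ccc2cc(/C=C3/SC(=O)NC3=O)ccc2c1)Nc1ccccn1`: in this assay compound 2 gives 17000 nM.

Compound 2 stands highest of the two numbers; the step of a 10-fold higher number from compound 1 to compound 2 (1.00 log units; beyond the scatter) is beyond the scatter. Compound 3 `Cc1cc(Br)ccc1NC(=O)COc1ccc2cc(/C=C3/SC(=O)NC3=O)ccc2c1` differs from compound 2 by 4-bromo-2-methylphenyl in place of pyridin-2-yl on an amide-type nitrogen. This change returns to an aromatic ring of carbon only on the amide-type nitrogen, much as in compound 1, so the step from compound 1 to compound 2 is expected to be roughly reversed. The estimated step of an 8.5-fold lower number from compound 2 to compound 3 (0.93 log units; beyond the scatter) is therefore a lower number. Compound 3 is expected to give about 2000 nM, between 600 nM and 6000 nM.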

Compound 3, half-maximal inhibitory concentration: 550 nM
The estimate for compound 3 lay 3.6-fold (0.56 log units) above the measured number, and the stated range ends above it.
By their numbers in this assay, from the lowest: compound 3; then compound 1; then compound 2.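

In this assay the aromatic ring of carbon only on the amide-type nitrogen again gives a lower number than pyridin-2-yl, with a 31-fold lower number from compound 2 to compound 3 (1.49 log units; beyond the scatter) in this pair. The 4-bromo-2-methylphenyl group also goes further than 4-methylphenyl, with a 3.1-fold lower number from compound 1 to compound 3 (0.49 log units; beyond the scatter) at the same place. Nothing available here explains these differences. The compounds shown do not separate the contribution of the bromine from that of the added methyl. They also leave open how a carboxylic acid or an amine on this ring, or a cyclohexyl group in its place, would read.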